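Lipophilicity notes: thioester to propyl ketone in the dienoate series

A few compounds are considered here, and "the series" means these few. Any claim that something is new, unique, unknown or untested is made for them only; others in the source may bear on it.

Measured compounds, partition coefficient:
- compound 1, `C#CCCOC(=O)/C=C(C)/C=C/CC(C)CCCC(C)(C)OC`: 5.2
- compound 2, `C=CCOC(=O)/C=C(C)/C=C/CC(C)CCCC(C)(C)OC`: 5.53
- compound 3, `COC(C)(C)CCCC(C)C/C=C/C(C)=C/C(=O)SC`: 6.24

In a physicochemical assay for lipophilicity (a lower number here means a more polar compound, a higher number a more lipophilic compound), compound 3 stands highest of the three numbers. Its nearest neighbour is compound 2, with a number 0.71 log units higher from compound 2 to compound 3 (beyond the scatter), and the furthest is compound 1, with a number 1.04 log units higher from compound 1 to compound 3 (beyond the scatter). Between the two esters themselves the change is smaller: a number 0.33 log units higher from compound 1 to compound 2 (beyond the scatter).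

Compound 4, `CCCC(=O)/C=C(C)/C=C/CC(C)CCCC(C)(C)OC`, has not been measured in this assay. It differs from compound 3 in one place: propyl in place of methylsulfanyl on a carbonyl carbon. Within the data shown here, none of the measured steps changes a carbonyl carbon substituent into a plain alkyl chain; the steps that bear on it only loosely are the ones that altered the group on the carbonyl carbon, and both of those were beyond the scatter. Going from a methylsulfanyl group to a propyl group, the chain grows by one heavy atom while the single acceptor on that group is lost, and no clear direction follows from the series. The expected step is therefore small, a number 0.24 log units lower from compound 3 to compound 4 (within the scatter), and compound 4 is estimated at 6, with a range from 5.5 to 6.5.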

Compound 4, partition coefficient: 5.61
Estimate against measurement, compound 4: 0.39 log units above, within the range that was stated.
By their numbers in this assay, from the lowest: compound 1; then compounds 2 and 4 (each within the scatter of the next); then compound 3.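

In this assay the carbonyl carbon proves sensitive to an alkyl group as well as to a change of heteroatom group: a number 0.63 log units lower from compound 3 to compound 4 (beyond the scatter) at this place, so propyl does not reproduce methylsulfanyl. Against the esters the result divides, with a number 0.08 log units higher from compound 2 to compound 4 (within the scatter) for allyloxy and a number 0.41 log units higher from compound 1 to compound 4 (beyond the scatter) for (but-3-yn-1-yl)oxy, which leaves propyl and allyloxy indistinguishable here while (but-3-yn-1-yl)oxy stays apart from propyl. Compound 3 remains the highest of the four, with its steps to all the others beyond the scatter, so within this set the top number goes with methylsulfanyl alone.

On these data alone, whether a longer alkyl chain, an amine or a carboxylic acid on the carbonyl carbon would follow propyl remains open. Nothing available accounts for the size of these steps.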